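Mirror image of a compound that showed no measurable inhibition

The source may report more compounds than this note shows. Statements on the series, on what has been measured and on what is new or still open speak of the compounds shown alone.

Measured so far in a functional assay on HL-60 cells (Homo sapiens) for cytotoxicity, read by WST assay, with a stated time of 48 h; a higher number here means a weaker inhibitor, a lower number a stronger inhibitor:
compound 1 `COc1cc(C(c2ccc(O)c(OC)c2)[C@@H](C)[C@@H](C)CF)ccc1O`: 38000 nM
compound 2 `COc1ccc(C(c2ccc(OC)c(OC)c2)[C@@H](C)[C@@H](C)CO)cc1OC`: > 100000 nM, a limit of the assay, not a number
compound 3 `CC[C@H](C(C)C)C(c1ccc(O)c(OC)c1)c1ccc(O)c(OC)c1`: 16000 nM

For the measured compounds named here, compound 1 and compound 3 differ in one place, and the step of a 2.4-fold lower number from compound 1 to compound 3 (0.38 log units; beyond the scatter) is the only measured step available. On these data alone, compound 2 stands apart from both of them: in this assay compound 2 reaches only the limit > 100000 nM, which is the limit of > 100000 nM in this assay, at which 1 of the 3 values shown sits, so its true potency is unknown beyond being weak.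

The unmeasured compound 4 `COc1ccc(C(c2ccc(OC)c(OC)c2)[C@H](C)[C@H](C)CO)cc1OC` differs from compound 2 as follows: the two compounds have the same atoms and bonds and differ only in configuration as drawn: 2 of 2 stereo elements differ (all stereocentres are inverted: mirror images); a stereocentre at a saturated chain carbon is drawn R in compound 2 and S in compound 4; a stereocentre at a saturated chain carbon is drawn R in compound 2 and S in compound 4. Going by the values given here, no measured step involves a change of configuration alone, and compound 1 and compound 3 differ from compound 2 in more than one place, so the measured step of a 2.4-fold lower number from compound 1 to compound 3 (0.38 log units; beyond the scatter) does not bear on this change. Without evidence for either direction, compound 4 is expected to sit near compound 2, most likely again at the limit.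

Compound 4 is therefore estimated at 100000 nM, within 30000 nM to 300000 nM, which means an expected step of a number no higher from compound 2 to compound 4 (the limit leaves the size open).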

Compound 4, half-maximal inhibitory concentration: > 100000 nM
Compound 4: a limit, no number (the forecaster's own chance of this, stated with the estimate: 70%); the middle value lies on the limit itself.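

Compound 2 and compound 4 both sit at a limit of the assay rather than at a number, so no step between them can be read: the limit of > 100000 nM in this assay, at which 2 of the 4 values shown sit.

The compounds shown leave open how weak each mirror image truly is, and whether inverting both stereocentres changes potency at all.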